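Swapping the Ester Group on Compound 2

This account rests on a few compounds, and the source may have more. Where it says the series, first, only, none or still open, it means among the compounds named here.

Values in a functional assay on HL-60 cells (Homo sapiens) for inhibition, read by luminescence, with a stated time of 72 h, tested at 5 uM (on this read-out lower numbers stand for less inhibition of growth and higher numbers for more inhibition of growth at the one concentration tested), so far
Compound 1 `C=CS(=O)(=O)NC/C=C/c1cc(OC)cc(O)c1C(=O)OCC1CCCCC1` gives 7.5%
Compound 2 `COc1cc(O)c(C(=O)OC(C)C)c(/C=C/CN2C(=O)C=CC2=O)c1` gives 65.7%

Of these two compounds, compound 2 stands highest, and its lead over compound 1 lies beyond the scatter. Compound 3 `COc1cc(O)c(C(=O)OCC2CCCCC2)c(/C=C/CN2C(=O)C=CC2=O)c1` has not yet been measured. It differs from compound 2 in one place cyclohexylmethyl in place of isopropyl on an oxygen next to a carbonyl group with cyclohexylmethyl in place of isopropyl on an oxygen next to a carbonyl group. Going by the values given here, no measured pair isolates this change. Compound 1 carries the same cyclohexylmethyl and gives 7.5% but also differs from compound 2 elsewhere, so it offers only a weak guide. The expected a number 8.7 percentage points lower from compound 2 to compound 3 (within the scatter) is a small fall in this assay and is not expected to lie clearly beyond the scatter. The estimate for compound 3 is 57% and the expected range runs from 25% to 85% on this measure.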

Compound 3, percent growth inhibition at one concentration: 71%
Beside the measured number, compound 3's estimate is 14 percentage points below it; low and high end bracket the measured number.
By their numbers in this assay, from the lowest: compound 1; then compounds 2 and 3 (each within the scatter of the next).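

In this assay, going by these compounds alone, a number 5.3 percentage points higher from compound 2 to compound 3 (within the scatter), so this pair shows for the first time that cyclohexylmethyl can stand in place of isopropyl on an oxygen next to a carbonyl group without a difference beyond the scatter. With cyclohexylmethyl present in both compounds, a number 63.5 percentage points higher from compound 1 to compound 3 (beyond the scatter), which places the large gap at the group on the saturated chain carbon bound to a double-bonded chain carbon, and not at the cyclohexylmethyl. No measurement at hand explains either step.

The compounds shown leave open whether a free carboxylic acid, an amide or a long unbranched alkyl chain would fit in place of this ester group. They also leave open whether compound 2 and compound 3 would stay this close at other concentrations, since each has a reading at only one.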